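Replacing a Chlorophenyl with a Methylphenyl on the Ring Nitrogen

A few compounds are considered here, and "the series" means these few. Any claim that something is new, unique, unknown or untested is made for them only; others in the source may bear on it.

Compound 1 `Cc1nc(Nc2ccc(Cl)cc2)sc1C(=O)/C=C/c1ccccc1`: > 25000 nM
Compound 2 `Cc1nc(Nc2ccc(Cl)cc2)sc1C(=O)/C=C/c1ccc(Cl)cc1`: > 25000 nM

Of the compounds shown here, two sharing one core have been tested for their ability to kill a human gastric cancer cell line. In a functional assay on BGC-823 cells (Homo sapiens) for cytotoxicity, read by MTT assay (a lower number here means a stronger inhibitor, a higher number a weaker inhibitor), compound 1 gives > 25000 nM, which is a limit of the assay rather than a measured number. Compound 2 likewise gives > 25000 nM, again a limit. The step that the two limits leave unreadable from compound 1 to compound 2 is therefore unreadable, because both values sit at the limit of > 25000 nM in this assay, at which 2 of the 2 values shown sit. Nothing is known about how far either compound lies beyond that point.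

Compound 3 `Cc1cccc(Nc2nc(C)c(C(=O)/C=C/c3ccccc3)s2)c1` differs from compound 1 by 3-methylphenyl in place of 4-chlorophenyl on a nitrogen on an aromatic ring. Within the data shown here, no measured step touches this position, and the one step that is known says nothing about size or direction. On that basis compound 3 is expected to stay at the limit as well, so the step that the limit leaves unreadable from compound 1 to compound 3 is expected to be unreadable in the same way. The estimate for compound 3 is 30000 nM, within a range from 8000 nM to 120000 nM.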

Compound 3, half-maximal inhibitory concentration: 13600 nM
For compound 3 the middle estimate is 2.2-fold (0.34 log units) above the measured one; the measured number falls inside the stated range.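

Compound 3 is the only compound shown that gives a real number rather than a limit in this assay, which makes this group on the nitrogen the first place in the series where a change registers at all. Putting 3-methylphenyl in place of 4-chlorophenyl gives an at least 1.8-fold lower number from compound 1 to compound 3 (0.26 log units; that floor lies within the scatter). This figure is only a floor: the true step may be larger, but on this evidence alone it cannot be separated from the ordinary variation between repeated measurements.

The change also alters two things at once, the chlorine giving way to a methyl group and the substituent moving from the 4 to the 3 position of the ring, so the compounds shown leave open which of these matters; 4-methylphenyl or 3-chlorophenyl on the same nitrogen would pull the two apart. They also leave open whether a quite different substituent on this ring, such as an amine or a carboxylic acid, would bring the number lower still or return it to the limit.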